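The compounds below may be only part of what the source reports. "The series", "measured", "known", "first", "only" and "open" are said of these compounds alone.

For the measured compounds named here, compound 2 `CCN(CC)CCCOc1cc2ncnc(Nc3nc4ccc(C(=O)Nc5c(C)cccc5Cl)cc4s3)c2cc1OC` stands second highest of the three numbers so far in a functional assay on K562 cells (Homo sapiens) for cytotoxicity, read by WST assay, with a stated time of 72 h; a higher number here means a weaker inhibitor, a lower number a stronger inhibitor. Compound 1 `CCN(CC)CCCOc1cc2ncnc(Nc3nc4ccc(C(=O)Nc5c(C)cccc5C)cc4s3)c2cc1OC` gives 28400 nM, compound 2 gives 9600 nM, and compound 3 `COc1cc2c(Nc3nc4ccc(C(=O)Nc5c(C)cc(C)cc5C)cc4s3)ncnc2cc1OCCCN1CCCCC1C` gives 3500 nM. Going by the values given here, the one step between compounds that differ in a single place is a 3.0-fold lower number from compound 1 to compound 2 (0.47 log units; beyond the scatter), the replacement of a methyl by a chloro on an aromatic carbon. Compound 3 differs from compound 2 in more than one place, so its value shows only where it lies, a lower number than compound 2.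

Compound 4 `COc1cc2c(Nc3nc4ccc(C(=O)Nc5c(C)cccc5Cl)cc4s3)ncnc2cc1OCCCN1CCCC1` is the next compound to be measured in this assay. It differs from compound 2 in one place: pyrrolidin-1-yl in place of diethylamino on a saturated chain carbon, three bonds along the chain from an oxygen on an aromatic ring.

Among the compounds with values here, none of the measured steps bears on this change. Within the data shown here, the only single-place step, a 3.0-fold lower number from compound 1 to compound 2 (0.47 log units; beyond the scatter), concerns a different position, and nothing among the measured compounds shows the effect of exchanging the amine at the end of the propyl chain while all else is held fixed. The expectation is therefore that the number for compound 4 stays close to that of compound 2, with a step of no change at the digits printed from compound 2 to compound 4 (within the scatter) that is not expected to go beyond the scatter. Compound 4 is accordingly estimated at 9600 nM in this assay, with a range from 3500 nM to 26000 nM.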

Compound 4, half-maximal inhibitory concentration: 13300 nM
Compound 4: the middle estimate sits 1.4-fold (0.14 log units) below what was measured; the range from low to high includes it.
By their numbers in this assay, from the lowest: compound 3; then compounds 2 and 4 (each within the scatter of the next); then compound 1.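

In this assay, the exchange of the open diethylamino group for the ring of pyrrolidin-1-yl, on a saturated chain carbon three bonds along the chain from an oxygen on an aromatic ring, is a 1.4-fold higher number from compound 2 to compound 4 (0.14 log units; within the scatter). For the compounds shown here, this is the first measured view of the amine at the end of the propyl chain with all else held fixed, and it shows that tying the two ethyl arms into one five-membered ring, with the same count of heavy atoms, does not separate the two compounds in this read-out. Nothing measured here explains this result or shows what the group at this place contributes to the number.

The compounds shown leave open whether this holds for amines of other ring size or make-up, such as piperidin-1-yl, morpholin-4-yl or dimethylamino at the end of the same chain, since a single pair says nothing about them. They also leave open whether 2-(pyrrolidin-1-yl)ethyl, a shorter chain, or a butyl chain carrying the same ring would read alike, and whether the exchange behaves the same with methyl in place of chloro on the aromatic ring.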